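A Further Methoxy on the Shared Core

This account rests on a few compounds, and the source may have more. Where it says the series, first, only, none or still open, it means among the compounds named here.

Measured so far in a functional assay on A 172 cells (Homo sapiens) for cytotoxicity, read by colorimetric assay and MTT assay; on this read-out higher numbers stand for weaker inhibition and lower numbers for stronger inhibition:
- compound 1 `COc1cccc2cc(-c3ccccc3)c(O)nc12`: 10000 nM
- compound 2 `COc1ccc(-c2cc3cccc(OC)c3nc2O)cc1`: 10000 nM

In this assay compound 2 gives 10000 nM, level with compound 1 at the digits shown. For the measured compounds named here, no other compound has yet been measured for comparison, so the series offers only this one pair.

Compound 3 `COc1ccc(-c2cc3c(OC)ccc(OC)c3nc2O)cc1` differs from compound 2 in a single place: methoxy in place of hydrogen on an aromatic carbon. The new methoxy stands on an aromatic carbon, para to a methoxy group.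

Going by the values given here, only one measured step bears on this change. It is also a methoxy in place of hydrogen on an aromatic carbon, and it reads no change at the digits printed from compound 1 to compound 2 (within the scatter), which lies within the scatter. That is thin evidence, since a single step cannot show how much the place of the group matters. It gives no reason to expect a move in either direction, though the range should stay wide. The expected step is no change at the digits printed from compound 2 to compound 3 (within the scatter), so none beyond the scatter is anticipated. For compound 3 the estimated value is 10000 nM, with an expected range from 3000 nM to 20000 nM.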

Compound 3, half-maximal inhibitory concentration: 10000 nM
For compound 3 middle estimate and measured number coincide at the digits printed, and the stated range covers the measured number.
By their numbers in this assay, from the lowest: compounds 1, 2 and 3 (each within the scatter of the next).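

In this assay, methoxy in place of hydrogen on an aromatic carbon of the six-membered ring of carbon only, para to a methoxy group, gives no change at the digits printed from compound 2 to compound 3 (within the scatter). This position, ortho to a fused ring and meta to a fused ring, therefore now has a reading of its own, and the same change has been followed in a second place on the shared core, alongside no change at the digits printed from compound 1 to compound 2 (within the scatter), with neither step beyond the scatter. Nothing among the data offers an explanation for this result.

The compounds shown leave open whether a group other than methoxy on this aromatic carbon, such as an amine, a carboxylic acid or a longer chain, would give a different reading in this assay. For the compounds shown here, they also leave open whether any change to the shared core can move the value away from the level common to these compounds, as methoxy in place of hydrogen is the only change represented here.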